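The source may hold more compounds than are shown below. What is called first, only, known or untested is meant among the compounds shown, and "the series" means these compounds.

Measured compounds:
compound 1, `CCCCCCNc1ccc([N+](=O)[O-])cc1S(N)(=O)=O`, 3.8%
compound 2, `CCCCCCCCNc1ccc([N+](=O)[O-])cc1S(N)(=O)=O`, 5.8%
compound 3, `CCCCCCNc1ccc(C(=O)O)cc1S(N)(=O)=O`, 4.9%

All three were tested in an assay on HEK293 cells for inhibition of solute carrier family 12 member 2 (Homo sapiens), read by fluorescence, with a stated time of 30 min, tested at 100 uM; a lower number here means a weaker effect, a higher number a stronger effect of the compound at the concentration tested. Compound 1 and compound 2 differ by ethyl in place of hydrogen on a saturated chain carbon, six bonds along the chain from a nitrogen on an aromatic ring, and that change gave a number 2 percentage points higher from compound 1 to compound 2 (within the scatter). The core of compound 3 differs from the core of compound 1 by carboxy in place of nitro on an aromatic carbon, with a number 1.1 percentage points higher from compound 1 to compound 3 (within the scatter). Compound 4, `CCCCCCCCNc1ccc(C(=O)O)cc1S(N)(=O)=O`, has not been measured in this assay; it differs from compound 3 by ethyl in place of hydrogen on a saturated chain carbon, six bonds along the chain from a nitrogen on an aromatic ring, the same change that separates compound 1 from compound 2, made here on the core of compound 3. Since that change produced a number 2 percentage points higher from compound 1 to compound 2 (within the scatter), the step from compound 3 to compound 4 is expected to be of similar size, a number 2.1 percentage points higher from compound 3 to compound 4 (within the scatter). For compound 4 an estimate of 7% is therefore given, with a range from -1% to 15%.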

Compound 4, a percentage reported as inhibition, at one concentration (the size of the read-out at that concentration, not a potency): 24%
Estimate against measurement, compound 4: 17 percentage points below; measured number outside the range, above it.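

In this assay, ethyl in place of hydrogen on the carboxy core gave a number 19.1 percentage points higher from compound 3 to compound 4 (beyond the scatter), and carboxy in place of nitro on the longer chain gave a number 18.2 percentage points higher from compound 2 to compound 4 (beyond the scatter). The chain change therefore did not carry over from one core to the other at a fixed size: the same change on two cores in this assay, a number 2 percentage points higher (within the scatter) from compound 1 to compound 2 and a number 19.1 percentage points higher (beyond the scatter) from compound 3 to compound 4, 17.1 percentage points apart, beyond the scatter of two such steps The nitro-to-carboxy change behaved likewise, so the two changes cannot be treated as independent in these four compounds, although this does not show why they interact or whether the same would hold on any other core: the same change on two cores in this assay, a number 1.1 percentage points higher (within the scatter) from compound 1 to compound 3 and a number 18.2 percentage points higher (beyond the scatter) from compound 2 to compound 4, 17.1 percentage points apart, beyond the scatter of two such steps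

The compounds shown leave open whether a longer chain on the carboxy core would raise the number further. They also leave open whether an amide in place of the carboxylic acid would preserve the gain.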